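The compounds below may be only part of what the source reports. "The series", "measured", "known", "first", "only" and "open" are said of these compounds alone.

Among the measured compounds shown here, compound 2 `C1CCC(C(CC2CCCCN2)C2CCOCC2)CC1` stands at the highest of the two numbers so far: in an assay on isolated protein (strain Wistar) for inhibition of carnitine O-palmitoyltransferase 1, muscle isoform (Rattus norvegicus), read by spectrophotometry, with stated times of 3 min and 3.5 min (on this read-out lower numbers stand for stronger inhibition and higher numbers for weaker inhibition), compound 2 gives 715000 nM. Its nearest neighbour is compound 1 `C1CCC(C(CC2CCCCN2)C2CCCC2)CC1`, which in this assay gives 11000 nM; the step of a 65-fold higher number from compound 1 to compound 2 (1.81 log units; beyond the scatter) is the only one measured in the series. Compound 3 `OC1CCC(C(CC2CCCCN2)C2CCCCC2)CC1` is not yet measured. It differs from compound 2 by 4-hydroxycyclohexyl in place of oxan-4-yl on a saturated chain carbon bound to a saturated chain carbon and a saturated ring carbon. For the measured compounds named here, the one measured step bears only loosely on this change: it shows how far the number rose when cyclopentyl gave way to oxan-4-yl at the same place, and compound 3 returns to a six-membered ring of carbon only, now as 4-hydroxycyclohexyl. On that basis a lower number than compound 2 is expected for compound 3 in this assay, though by less than the measured step from compound 1 to compound 2: the estimated step is a 6.0-fold lower number from compound 2 to compound 3 (0.78 log units; beyond the scatter). The estimate for compound 3 in this assay is 120000 nM, with a range from 20000 nM to 700000 nM.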

Compound 3, half-maximal inhibitory concentration: 475000 nM
Estimate against measurement, compound 3: 4.0-fold (0.60 log units) below; low and high end bracket the measured number.
By their numbers in this assay, from the lowest: compound 1; then compounds 3 and 2 (each within the scatter of the next).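

In this assay, 4-hydroxycyclohexyl and oxan-4-yl on this saturated chain carbon give nearly the same result, with a 1.5-fold lower number from compound 2 to compound 3 (0.18 log units; within the scatter). Moving the oxygen from the ring into a hydroxy group on a ring of carbon only therefore does not recover the number seen with cyclopentyl, as a 43-fold higher number from compound 1 to compound 3 (1.64 log units; beyond the scatter) shows. No measurement here accounts for the closeness of compounds 2 and 3 or their distance from compound 1.

Both oxygen-bearing groups differ from cyclopentyl in ring size as well as in carrying oxygen, so these compounds do not separate the two changes. A plain cyclohexyl at this place would address that question, while 4-aminocyclohexyl would show whether an amine behaves like the hydroxy group.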